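One Five-Membered Ring for Another on the Amide

The source may hold more compounds than are shown below. What is called first, only, known or untested is meant among the compounds shown, and "the series" means these compounds.

Measured so far:
compound 1 `Cc1nc(C(=O)Nc2ccc(Cl)c(-c3nnc4c(Cl)cccn34)c2)cs1` — 74300 nM
compound 2 `O=C(Nc1ccc(Cl)c(-c2nnc3c(Cl)cccn23)c1)c1ccc(Cl)cc1` — > 100000 nM, a limit of the assay
compound 3 `CS(=O)(=O)c1ccc(C(=O)Nc2ccc(Cl)c(-c3nnc4c(Cl)cccn34)c2)cc1` — > 100000 nM, a limit of the assay

In a functional assay on U-251 cells (Homo sapiens) for antiproliferative activity, read by MTT assay, with a stated time of 72 h (a higher number here means a weaker inhibitor, a lower number a stronger inhibitor), compound 1 stands alone with a real number, 74300 nM. Compound 2 gives only the limit > 100000 nM. Compound 3 likewise gives only the limit > 100000 nM. Both steps away from compound 1 therefore carry a floor rather than a size: an at least 1.3-fold higher number from compound 1 to compound 2 (0.12 log units; that floor lies within the scatter) and an at least 1.3-fold higher number from compound 1 to compound 3 (0.12 log units; that floor lies within the scatter), each set by the limit of > 100000 nM in this assay, at which 2 of the 3 values shown sit. Compound 4 `O=C(Nc1ccc(Cl)c(-c2nnc3c(Cl)cccn23)c1)c1ccon1` changes compound 1 at the same place, but differently: 1,2-oxazol-3-yl in place of 2-methyl-1,3-thiazol-4-yl on a carbonyl carbon. The two measured steps replaced the five-membered ring with a substituted phenyl and lost all readable activity; compound 4 instead keeps a five-membered aromatic ring with two hetero atoms. Going by the values given here, no measured pair tests such a swap, so the expectation leans on the similarity of the rings. Compound 4 is expected to show a 1.2-fold higher number from compound 1 to compound 4 (0.08 log units; within the scatter), a step that need not exceed the scatter. The estimate for compound 4 is 90000 nM, within 40000 nM to 200000 nM, with a fair chance that this assay again reports only a limit.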

Compound 4, half-maximal inhibitory concentration: > 100000 nM
Compound 4: only a limit was reported; the forecaster's own chance of this, stated with the estimate: 45%; middle value at least 1.1-fold (0.04 log units) away from the limit.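

Keeping a five-membered aromatic ring on the carbonyl carbon, here 1,2-oxazol-3-yl, does not give a readable number in this assay, so the substituted phenyl groups are no longer the only replacements that end at the limit. As far as these compounds go, the change gives an at least 1.3-fold higher number from compound 1 to compound 4 (0.12 log units; that floor lies within the scatter), so the real size of this step remains unknown. The steps from compound 2 and from compound 3 to compound 4 cannot be read, because all three compounds end at the same limit: the limit of > 100000 nM in this assay, at which 3 of the 4 values shown sit.

Going by these compounds alone, compound 1 remains the only compound with a real number, so it stays open whether the methyl group or the sulfur of its 2-methyl-1,3-thiazol-4-yl ring matters here. Also open, from the compounds shown here alone, is how an amine on that ring, or a longer chain in place of its methyl, would read.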